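A few compounds are considered here, and "the series" means these few. Any claim that something is new, unique, unknown or untested is made for them only; others in the source may bear on it.

Measured so far in an ADME assay on Huh-7 cells (Homo sapiens) for cytotoxicity; on this read-out lower numbers stand for higher toxicity in this test and higher numbers for lower toxicity in this test:
- compound 1, `O=c1cc(CNCc2ccccc2Br)oc2ccc(O)c(O)c12`, > 100000 nM
- compound 2, `O=c1cc(CNCc2ccccc2[N+](=O)[O-])oc2ccc(O)c(O)c12`, 41300 nM

Compound 1 is known in this assay only by a limit, not by a number: it sits at the limit of > 100000 nM in this assay, at which 1 of the 2 values shown sits. Compound 2, in which a nitro stands in place of the bromo on an aromatic carbon, gives a number, 41300 nM. Among the measured compounds shown here, the only measured step is an at least 2.4-fold lower number from compound 1 to compound 2 (0.38 log units; beyond the scatter); it shows that an exchange of the group on that aromatic carbon can move the read-out by at least that much.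

Compound 3, `Cc1ccccc1CNCc1cc(=O)c2c(O)c(O)ccc2o1`, differs from compound 1 by methyl in place of bromo on an aromatic carbon. For the measured compounds named here, no measured step involves a methyl, so the step from compound 1 to compound 2 is the only guide, and it concerns a different entering group. Compound 3 is therefore expected to remain close to the limit at which compound 1 stands, with the estimate placed at 100000 nM and a range from 45000 nM to 220000 nM. That estimate corresponds to an expected a number no higher from compound 1 to compound 3 (the limit leaves the size open), which would be within the scatter of this assay.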

Compound 3, half-maximal cytotoxic concentration: 52200 nM
Compound 3: middle estimate off by 1.9-fold (0.28 log units), on the high side; the measured number falls inside the stated range.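

At the aromatic carbon ortho to a large group, methyl and nitro are not told apart in this assay, with a 1.3-fold higher number from compound 2 to compound 3 (0.10 log units; within the scatter), so the two entering groups cannot be ordered on this read-out. The exchange of bromo for methyl gives an at least 1.9-fold lower number from compound 1 to compound 3 (0.28 log units; that floor lies within the scatter), so unlike the step to nitro, this step is not shown to go beyond the scatter, and its true size remains open. Compound 1 remains known only by a limit, so bromo is the one group of the three shown without a number: the limit of > 100000 nM in this assay, at which 1 of the 3 values shown sits.

Going by these compounds, how far compound 1 truly lies from the other two compounds stays open, and with it whether bromo really differs from methyl at this place. Also open, on these data alone, is whether a chloro, a methoxy or an amine on the same aromatic carbon would give a number like those of compound 2 and compound 3 or would stand at the limit as compound 1 does.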